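Replacing a Chain-End Hydroxy with Nonyl in Lymphocytes

This account rests on a few compounds, and the source may have more. Where it says the series, first, only, none or still open, it means among the compounds named here.

Compound 1, `Cc1c(N(C)C)nc(CCCCCCCCCCO)c(O)c1C`: 74%
Compound 2, `CCCCCCCCCCCCCCCCc1c(C)c(N2CCC2)nc(C)c1O`: 92%
Compound 3, `CCCCCCCCCCCCCCCCCCCc1c(C)c(N(C)C)nc(C)c1O`: 87%

Of the compounds shown here, three sharing one core have been tested in a functional assay on cells (Lymphocyte, Homo sapiens), read by trypan blue exclusion, with a stated time of 16 h, tested at 2.5 uM; on this read-out lower numbers stand for a weaker effect and higher numbers for a stronger effect at the one concentration tested. Compound 1 stands lowest of the three; compound 3 lies nearest to it and compound 2 furthest, and both gaps are beyond the usual scatter. Compound 4, `CCCCCCCCCCCCCCCCCCCc1nc(N(C)C)c(C)c(C)c1O`, has not yet been tested. It differs from compound 1 in one respect: nonyl in place of hydroxy on a saturated chain carbon, ten or more bonds along the chain from an aromatic carbon. Among the compounds with values here, no step between two measured compounds differing in a single place is available, so the expectation rests on the two compounds carrying a long saturated chain, compound 2 and compound 3, both reading higher than compound 1. A rise beyond the scatter is therefore expected, a number 11 percentage points higher from compound 1 to compound 4 (beyond the scatter). Compound 4 is expected to give 85%, within a range from 70% to 96%.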

Compound 4, a percentage reported as activity, at one concentration (the size of the read-out at that concentration, not a potency): 66%
Compound 4: the middle estimate sits 19 percentage points above what was measured; measured number outside the range, below it.
By their numbers in this assay, from the lowest: compounds 4 and 1 (each within the scatter of the next); then compounds 3 and 2 (each within the scatter of the next).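

In this assay nonyl in place of hydroxy, on a saturated chain carbon, gives a number 8 percentage points lower from compound 1 to compound 4 (within the scatter) and so the two compounds cannot be told apart. This first single-place comparison shows that, at this position, this read-out does not separate a chain ending in hydroxy from one extended by nonyl. No supporting measurement explains this result. As far as these compounds go, whether an amine or a carboxylic acid at the same place would separate from hydroxy remains open.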